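Replacing the group on sulfur in compound 2

The compounds below may be only part of what the source reports. "The series", "measured", "known", "first", "only" and "open" are said of these compounds alone.

Compound 1 `COc1ccc(CN(C(=O)CSc2nc3cc(Cl)ccc3s2)c2cc(OC)c(OC)c(OC)c2)cc1O` gives 11200 nM
Compound 2 `COc1ccc(CN(C(=O)CSc2nc3c(C)cccc3s2)c2cc(OC)c(OC)c(OC)c2)cc1O` gives 12300 nM

Within the data shown here, in a functional assay on PC-3 cells (Homo sapiens) for antiproliferative activity, read by MTT assay, with a stated time of 48 h (a lower number here means a stronger inhibitor, a higher number a weaker inhibitor), compound 2 stands level with compound 1 , the only other measured compound. Compound 3 `COc1ccc(CN(C(=O)CSc2nc3cc(Br)ccc3s2)c2cc(OC)c(OC)c(OC)c2)cc1O` departs from compound 2 by a single change: a group of 10 heavy atoms (7 carbon, 1 nitrogen, 1 sulfur, 1 bromine; one five-membered aromatic ring with 2 hetero atoms, one six-membered aromatic ring of carbon only) in place of a group of 10 heavy atoms (8 carbon, 1 nitrogen, 1 sulfur; one five-membered aromatic ring with 2 hetero atoms, one six-membered aromatic ring of carbon only), on a sulfur. Among the measured compounds shown here, the one measured step that bears on this also exchanged the group on that sulfur. This step, a 1.1-fold higher number from compound 1 to compound 2 (0.04 log units; within the scatter), stayed within the scatter, so no change beyond the scatter is expected in this assay. The expected step is a 1.1-fold lower number from compound 2 to compound 3 (0.03 log units; within the scatter). For compound 3 the estimated value is 11500 nM, with an expected range from 6000 nM to 22000 nM.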

Compound 3, half-maximal inhibitory concentration: 8210 nM
For compound 3 the middle estimate is 1.4-fold (0.15 log units) above the measured one; measured number inside the range.
By their numbers in this assay, from the lowest: compounds 3, 1 and 2 (each within the scatter of the next).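

Bromo in place of chloro on an aromatic carbon gives a 1.4-fold lower number from compound 1 to compound 3 (0.13 log units; within the scatter) in this assay, so this exchange of one halogen for the other, at an unchanged place on the group, stays within the scatter. Exchanging the 4-methyl-1,3-benzothiazol-2-yl group on the sulfur gives a 1.5-fold lower number from compound 2 to compound 3 (0.18 log units; within the scatter) and likewise stays within it, so all three groups on this sulfur remain level. The compounds shown leave open whether an amine or a carboxylic acid in place of the halogen would produce a step beyond the scatter. No evidence is available that bears on these results.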